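Series notes: coumarin-bearing stilbene enones in MAO-B inhibition

The compounds below may be only part of what the source reports. "The series", "measured", "known", "first", "only" and "open" are said of these compounds alone.

Measured compounds:
compound 1, `COc1ccc(/C=C/c2cc(OC)cc(OC)c2/C=C/C(=O)c2cc3ccc(Cl)cc3oc2=O)cc1`: 7360 nM
compound 2, `COc1ccc(/C=C/c2cc(OC)cc(OC)c2/C=C/C(=O)c2cc3cccc(C)c3oc2=O)cc1`: 20000 nM
compound 3, `COc1ccc(/C=C/c2cc(OC)cc(OC)c2/C=C/C(=O)c2cc3cc(C)ccc3oc2=O)cc1`: 5090 nM

In an assay on isolated protein for inhibition of Amine oxidase [flavin-containing] B (Homo sapiens), read by fluorescence, with a stated time of 15 min (a lower number here means a stronger inhibitor, a higher number a weaker inhibitor), compound 3 gives the lowest number of the three. Against compound 1 the gap is small, a 1.4-fold lower number from compound 1 to compound 3 (0.16 log units; within the scatter), so the two cannot be ordered. Against compound 2 the gap is larger, a 3.9-fold lower number from compound 2 to compound 3 (0.59 log units; beyond the scatter), and the whole series spans only a modest range, a 2.7-fold higher number from compound 1 to compound 2 (0.43 log units; beyond the scatter) covering the rest.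

Compound 4, `COc1ccc(/C=C/c2cc(OC)cc(OC)c2/C=C/C(=O)c2cc3cc(Br)ccc3oc2=O)cc1`, differs from compound 3 by bromo in place of methyl on an aromatic carbon. For the measured compounds named here, no measured pair swaps a halogen for a methyl at the same carbon. The nearest guide is compound 1 against compound 3, where a chloro on the same fused ring at another carbon sits within the scatter of the methyl, a 1.4-fold lower number from compound 1 to compound 3 (0.16 log units; within the scatter). A halogen in this region therefore seems tolerated, and a step beyond the scatter is not expected in this assay in either direction.

Compound 4 is estimated at 4500 nM, with a range of 1800 nM to 12000 nM, the expected step being a 1.1-fold lower number from compound 3 to compound 4 (0.05 log units; within the scatter).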

Compound 4, half-maximal inhibitory concentration: > 60000 nM
Compound 4: only a limit was reported; the forecaster's own chance of this, stated with the estimate: 5%; middle value at least 13-fold (1.12 log units) from the limit.
By their numbers in this assay, from the lowest: compounds 3 and 1 (each within the scatter of the next); then compound 2. At a limit, above all of these: compound 4.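

In this assay compound 4 is reported only as a limit, not as a number: the limit of > 60000 nM in this assay, at which 1 of the 4 values shown sits.

For the compounds shown here, at this aromatic carbon, meta to a fused ring and para to a fused ring, bromo in place of methyl is a large change, with an at least 11-fold higher number from compound 3 to compound 4 (1.07 log units; beyond the scatter), so this carbon responds to the exchange of one heavy atom, which the earlier compounds did not show. The other steps, an at least 3.0-fold higher number from compound 2 to compound 4 (0.47 log units; beyond the scatter) and an at least 8.1-fold higher number from compound 1 to compound 4 (0.91 log units; beyond the scatter), also lie beyond the scatter, so a halogen on this fused ring is not tolerated as such, although chloro at another carbon stays level with compound 3, with a 1.4-fold lower number from compound 1 to compound 3 (0.16 log units; within the scatter).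

The compounds shown leave open whether a fluoro or an ethyl at this carbon would behave like methyl or like bromo. On these data alone, how far compound 4 lies beyond its limit also stays open.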